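The source may hold more compounds than are shown below. What is called first, only, known or untested is meant among the compounds shown, and "the series" means these compounds.

Working notes on the series.

Compound 1 `Cc1ncc(S(=O)(=O)NC(=O)NC/C=C2\CCCc3cnn(Cc4ccc(Cl)cc4Cl)c32)s1` gives 9 nM in a functional assay on CHO-K1 cells for antagonist activity at prostaglandin E2 receptor EP3 subtype (Homo sapiens), read by TR-FRET and cAMP accumulation, with a stated time of 30 min; on this read-out lower numbers stand for stronger inhibition and higher numbers for weaker inhibition. Compound 2 `CS(=O)(=O)c1ccc(-n2ncc3c2/C(=C/CNC(=O)NS(=O)(=O)c2cc(Cl)c(Cl)s2)CCC3)cc1` gives 30 nM in this assay, and compound 3 `O=C(NC/C(F)=C1\CCCc2cnn(Cc3ccc(C(F)(F)F)cc3)c21)NS(=O)(=O)c1cc(Cl)c(Cl)s1` gives 52 nM. Of the three numbers, compound 1 has the lowest; the gaps to compound 2 and to compound 3 both lie beyond the scatter.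

Compound 4 `O=C(NC/C=C1\CCCc2cnn(Cc3ccc(Cl)cc3Cl)c21)NS(=O)(=O)c1cccs1` is not yet measured. Relative to compound 1 the change is thiophen-2-yl in place of 2-methyl-1,3-thiazol-5-yl on a sulfonyl sulfur. Among the measured compounds shown here, no step between measured compounds covers this exchange, so the direction has to be guessed.

A modest move toward a higher number, that is weaker inhibition, is expected; the step of a 2.0-fold higher number from compound 1 to compound 4 (0.30 log units; within the scatter) is an estimate only. For compound 4 the expected value is 18 nM, with a range from 6 nM to 60 nM.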

Compound 4, half-maximal inhibitory concentration: 28 nM
Estimate against measurement, compound 4: 1.6-fold (0.19 log units) below; low and high end bracket the measured number.
By their numbers in this assay, from the lowest: compound 1; then compounds 4, 2 and 3 (each within the scatter of the next).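

In this assay, among the compounds shown here, the group on the sulfonyl sulfur matters: a 3.1-fold higher number from compound 1 to compound 4 (0.49 log units; beyond the scatter) is the first exchange made in one place only, and it lies beyond the scatter. The exchange removes the ring nitrogen and the methyl together, and the step does not separate the two. Nothing available explains the size of this step.

Still open, on these data alone, is whether an unmethylated 1,3-thiazol-5-yl or a pyridine ring on the sulfonyl sulfur would give a number closer to compound 1 or to compound 4.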